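Piperidine in place of morpholine: what to expect

The source may report more compounds than this note shows. Statements on the series, on what has been measured and on what is new or still open speak of the compounds shown alone.

Three compounds have been measured in a functional assay on HeLa cells (Homo sapiens) for inhibition, read by MTT assay, with a stated time of 48 h; on this read-out lower numbers stand for stronger inhibition and higher numbers for weaker inhibition:
Compound 1, `COc1cc(-c2nc3cc(/C=C4\SC(=O)NC4=O)ccc3[nH]2)cc(OC)c1OC`: 1670 nM
Compound 2, `COc1cc(-c2nc3cc(/C=C4\SC(=O)N(CC(=O)N5CCOCC5)C4=O)ccc3[nH]2)cc(OC)c1OC`: 16300 nM
Compound 3, `COc1cc(OC)c(-c2nc3cc(/C=C4\SC(=O)N(CC(=O)N5CCOCC5)C4=O)ccc3[nH]2)cc1OC`: 510 nM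

Compound 2 stands highest of these three numbers, that is, it is the weakest inhibitor measured so far. Attaching the amide side chain to the ring nitrogen gave a 9.8-fold higher number from compound 1 to compound 2 (0.99 log units; beyond the scatter), and exchanging the trimethoxyphenyl pattern gave a 32-fold lower number from compound 2 to compound 3 (1.50 log units; beyond the scatter).

Compound 4, `COc1cc(-c2nc3cc(/C=C4\SC(=O)N(CC(=O)N5CCCCC5)C4=O)ccc3[nH]2)cc(OC)c1OC`, differs from compound 2 by piperidin-1-yl in place of morpholin-4-yl on a carbonyl carbon. Neither measured step touches this end of the side chain: one concerns whether the side chain is present at all, the other concerns the methoxy arrangement on the distant aryl ring. Among the compounds with values here, there is therefore no measured step that bears directly on this change, and no ground to expect a step beyond the scatter in this assay in either direction. The estimate for compound 4 is 13000 nM, with a range from 3500 nM to 45000 nM. This estimate corresponds to an expected 1.3-fold lower number from compound 2 to compound 4 (0.10 log units; within the scatter).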

Compound 4, half-maximal inhibitory concentration: 23300 nM
The estimate for compound 4 lay 1.8-fold (0.25 log units) below the measured number, and the stated range covers the measured number.
By their numbers in this assay, from the lowest: compound 3; then compound 1; then compounds 2 and 4 (each within the scatter of the next).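

In this assay the far end of the side chain is now probed directly: piperidin-1-yl in place of morpholin-4-yl on a carbonyl carbon, which exchanges the ring oxygen for carbon, gives a 1.4-fold higher number from compound 2 to compound 4 (0.16 log units; within the scatter) and so cannot be told apart from repeat-measurement noise. The side chain on the amide-type nitrogen now also raises the number with a second ring, as ((piperidin-1-yl)carbonyl)methyl in place of hydrogen gives a 14-fold higher number from compound 1 to compound 4 (1.14 log units; beyond the scatter) with the 3,4,5-trimethoxyphenyl group held constant. Nothing available here explains either step.

From the compounds shown here alone, whether the number would hold with a piperazin-1-yl ring, which carries a second nitrogen, or with a carboxylic acid at the end of the chain remains open. So does whether piperidin-1-yl would match morpholin-4-yl alongside the 2,4,5-trimethoxyphenyl group of compound 3.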